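Furan in Place of Phenyl on a Shared Pyridine-free Core

A few compounds are considered here, and "the series" means these few. Any claim that something is new, unique, unknown or untested is made for them only; others in the source may bear on it.

Measured compounds:
compound 1, `Oc1cccc(-c2cc(-c3cccc(Cl)c3)nc(-c3ccco3)c2)c1`, 2460 nM
compound 2, `Oc1cccc(-c2cc(-c3ccccc3)nc(-c3ccccc3Cl)c2)c1`, 2930 nM

Of the compounds shown here, two have been measured in a functional assay on HCT-15 cells (Homo sapiens) for cytotoxicity, read by CCK-8 assay and cell counting, with a stated time of 2 days; a lower number here means a stronger inhibitor, a higher number a weaker inhibitor. Compound 1 gives 2460 nM, and compound 2 gives 2930 nM. The two numbers sit within the scatter of each other, so nothing separates compound 2 from compound 1 on these data; the two compounds also differ in more than one place, so no single step can be read between them.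

Compound 3, `Oc1cccc(-c2cc(-c3ccco3)nc(-c3ccccc3Cl)c2)c1`, has not yet been measured. It differs from compound 2 in one place: furan-2-yl in place of phenyl on an aromatic carbon. The 2-chlorophenyl group and the 3-hydroxyphenyl group of compound 2 are kept.

Among the measured compounds shown here, no measured pair shows this change on its own. Compound 1 carries the same furan-2-yl group with a different chlorophenyl group and gives 2460 nM, a number within the scatter of compound 2. On that basis the expected step in this assay from compound 2 to compound 3 is small, a 1.2-fold lower number from compound 2 to compound 3 (0.07 log units; within the scatter), and not clearly beyond the scatter in either direction. Compound 3 is therefore estimated at 2500 nM, with a range from 1000 nM to 6000 nM.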

Compound 3, half-maximal inhibitory concentration: 2230 nM
Beside the measured number, compound 3's estimate is 1.1-fold (0.05 log units) above it; the measured number falls inside the stated range.
By their numbers in this assay, from the lowest: compounds 3, 1 and 2 (each within the scatter of the next).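

In this assay, among the compounds shown here, furan-2-yl in place of phenyl on the aromatic carbon next to the ring nitrogen gives a 1.3-fold lower number from compound 2 to compound 3 (0.12 log units; within the scatter) and so, for the first time, this change can be read on its own. At this position, with the 2-chlorophenyl and 3-hydroxyphenyl groups kept, a five-membered aromatic ring with one hetero atom stands in for a six-membered aromatic ring of carbon only, with no difference that this assay can separate from its scatter. The second new comparison, 2-chlorophenyl in place of 3-chlorophenyl on an aromatic carbon with furan-2-yl kept, gives a 1.1-fold lower number from compound 1 to compound 3 (0.04 log units; within the scatter) and so does not tell these two chlorophenyl groups apart either.

Whether any group at this position can move the number beyond the scatter stays open, since the compounds shown carry only phenyl and furan-2-yl there, and an amine, a carboxylic acid or a longer chain in that place would be a different kind of test. Nothing available speaks to the reason these numbers lie so close together.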